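The source may hold more compounds than are shown below. What is called first, only, known or untested is meant among the compounds shown, and "the series" means these compounds.

In a functional assay on MCF7 cells (Homo sapiens) for inhibition, read by sulforhodamine B assay, with a stated time of 48 h (a higher number here means a weaker inhibitor of growth, a lower number a stronger inhibitor of growth), compound 1 (`O=C(CCl)NC(=O)Nc1ccc(-c2ccccc2)cc1`) gives 3900 nM and compound 2 (`O=C(CCl)NC(=O)Nc1cccc(OC2CCCC2)c1`) gives 6200 nM while compound 3 (`O=C(CCl)NC(=O)Nc1ccc(OC2CCCCCC2)cc1`) gives 3600 nM on the same measure. Compound 2 thus stands level with the other two, its number lying within the scatter of each. Compound 4 (`O=C(CCl)NC(=O)Nc1cccc(Oc2ccccc2)c1`) differs from compound 2 in one place (phenyl in place of cyclopentyl on an oxygen on an aromatic ring) with phenyl in place of cyclopentyl on an oxygen on an aromatic ring. Among the measured compounds shown here, no measured pair shows this change directly. Compound 1 at 3900 nM and compound 3 at 3600 nM carry other groups yet stay within the scatter of compound 2 at 6200 nM so no step beyond the scatter is expected in this assay in either direction. The expected change a 1.4-fold lower number from compound 2 to compound 4 (0.14 log units; within the scatter) is small and stays within the scatter. For compound 4 the estimated value is 4500 nM and the expected range runs from 2000 nM to 10000 nM at its two ends.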

Compound 4, concentration for 50% growth inhibition: 8100 nM
Beside the measured number, compound 4's estimate is 1.8-fold (0.26 log units) below it; measured number inside the range.
By their numbers in this assay, from the lowest: compounds 3, 1, 2 and 4 (each within the scatter of the next, the first and the last beyond it).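

Among the compounds shown here, the first direct reading of phenyl in place of cyclopentyl on an oxygen on an aromatic ring in this assay gives a 1.3-fold higher number from compound 2 to compound 4 (0.12 log units; within the scatter) and so lies within the scatter. At this position, the measured step therefore does not separate the aromatic ring from the five-membered non-aromatic ring. No measurement shown here bears on why this is so. Going by these compounds, it remains open whether a longer chain or a benzyl group on that oxygen would give a step beyond the scatter.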